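From Amide-Type Link to Its Amino-Extended Analogue

The source may hold more compounds than are shown below. What is called first, only, known or untested is meant among the compounds shown, and "the series" means these compounds.

Of the compounds shown here, three sharing one core have been tested in a functional assay on SF-268 cells (Homo sapiens) for inhibition, read by sulforhodamine B assay, with a stated time of 48 h; on this read-out lower numbers stand for stronger inhibition of growth and higher numbers for weaker inhibition of growth. Compound 1 `COc1cc(-c2nn(-c3cccc(NC(=O)Nc4cc(C(F)(F)F)cc(C(F)(F)F)c4)c3)cc2-c2ccncc2)ccc1Cl` gives 978 nM and compound 3 `O=C(Nc1cccc(-n2cc(-c3ccncc3)c(-c3ccc(Cl)c(O)c3)n2)c1)Nc1ccc(Cl)c(Cl)c1` gives 1490 nM, while compound 2 `COc1cc(-c2nn(-c3cccc(NC(=O)c4cccc(C(F)(F)F)c4)c3)cc2-c2ccncc2)ccc1Cl` gives 2130 nM, the highest of the three numbers; its gap to compound 3 lies within the scatter, its gap to compound 1 beyond it. Compound 4 `COc1cc(-c2nn(-c3cccc(NC(=O)Nc4cccc(C(F)(F)F)c4)c3)cc2-c2ccncc2)ccc1Cl` awaits measurement. It differs from compound 2 by (3-(trifluoromethyl)phenyl)amino in place of 3-(trifluoromethyl)phenyl on a carbonyl carbon, so that its carbonyl link matches the kind carried by compound 1 and compound 3. Compound 1 reaches 978 nM with such a link, which supports an expectation of a modest step toward stronger inhibition. The step from a 1.6-fold lower number from compound 2 to compound 4 (0.21 log units; within the scatter) is expected to stay small. Compound 4 is estimated at 1300 nM, within 500 nM to 3500 nM.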

Compound 4, concentration for 50% growth inhibition: 1360 nM
Estimate against measurement, compound 4: 1.0-fold (0.02 log units) below; low and high end bracket the measured number.
By their numbers in this assay, from the lowest: compounds 1, 4, 3 and 2 (each within the scatter of the next, the first and the last beyond it).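

In this assay, for the compounds shown here, (3-(trifluoromethyl)phenyl)amino in place of 3-(trifluoromethyl)phenyl on a carbonyl carbon gives a 1.6-fold lower number from compound 2 to compound 4 (0.19 log units; within the scatter) as the first single-place reading of this change. Hydrogen in place of trifluoromethyl on an aromatic carbon gives a 1.4-fold higher number from compound 1 to compound 4 (0.14 log units; within the scatter) and so does not separate its pair either. Nothing measured here explains either step.

The compounds shown leave open whether a piperazine or a longer alkyl chain on the carbonyl carbon would move the number beyond the scatter. They also leave open what a carboxylic acid would give in place of trifluoromethyl on the aromatic carbon.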